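This account rests on a few compounds, and the source may have more. Where it says the series, first, only, none or still open, it means among the compounds named here.

Compound 3 `C[C@@H](NC(=O)C1(NC(=O)c2cncs2)CC1)c1ccc(-n2nc(Cl)c3ccccc32)cc1F` stands at the low end of the three numbers: in an in vivo ADME assay on the whole organism (strain Mongrel) for metabolic stability, with Canis familiaris (Canis lupus familiaris) as the target (on this read-out lower numbers stand for a shorter-lived compound and higher numbers for a longer-lived compound), compound 3 gives 4.3 h. Compound 1 `COc1ncc(C(=O)NC2(C(=O)N[C@H](C)c3ccc(-n4nc(Cl)c5ccccc54)cc3F)CC2)s1` gives 8.3 h in this assay, and compound 2 `C[C@@H](NC(=O)C1(NC(=O)c2cncc(Cl)n2)CC1)c1ccc(-n2nc(Cl)c3ccccc32)cc1F` gives 15.1 h. Within the data shown here, only the step of a 3.5-fold lower number from compound 2 to compound 3 (0.55 log units; beyond the scatter) goes beyond the scatter; the step of a 1.9-fold lower number from compound 1 to compound 3 (0.29 log units; within the scatter) and the step of a 1.8-fold higher number from compound 1 to compound 2 (0.26 log units; within the scatter) both stay within it, so compound 3 and compound 1 cannot be told apart on these numbers. Compound 4 `COc1cc(C(=O)NC2(C(=O)N[C@H](C)c3ccc(-n4nc(Cl)c5ccccc54)cc3F)CC2)on1` is not yet measured. Its change from compound 3 reads (3-methoxy-1,2-oxazol-5-yl in place of 1,3-thiazol-5-yl on a carbonyl carbon). Among the measured compounds shown here, no measured pair swaps one five-membered heteroaryl for another, so the nearest guide is compound 1, which bears a 2-methoxy-1,3-thiazol-5-yl on the carbonyl carbon and gives 8.3 h; the step of a 1.9-fold lower number from compound 1 to compound 3 (0.29 log units; within the scatter) suggests that a methoxy-bearing five-membered ring may return the number toward that of compound 1, though not by a step that must exceed the scatter. The estimate for compound 4 in this assay is therefore 7 h, between 3 h and 16 h. The expected step of a 1.6-fold higher number from compound 3 to compound 4 (0.21 log units; within the scatter) sits near the edge of the scatter.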

Compound 4, half-life: 20.8 h
Estimate against measurement, compound 4: 3.0-fold (0.47 log units) below, outside the stated range (above it).
By their numbers in this assay, from the lowest: compounds 3, 1, 2 and 4 (each within the scatter of the next, the first and the last beyond it).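

In this assay, a 3-methoxy-1,2-oxazol-5-yl on the carbonyl carbon lifts the half-life well clear of the 1,3-thiazol-5-yl (a 4.8-fold higher number from compound 3 to compound 4 (0.68 log units; beyond the scatter)). The methoxy group alone does not set the number, since the two methoxy-bearing five-membered rings also separate (a 2.5-fold higher number from compound 1 to compound 4 (0.40 log units; beyond the scatter)). The 3-methoxy-1,2-oxazol-5-yl and the 6-chloropyrazin-2-yl cannot be told apart at this position (a 1.4-fold higher number from compound 2 to compound 4 (0.14 log units; within the scatter)).

Still open, as far as these compounds go, is how much of the step belongs to the ring and how much to its substituent; the plain 1,2-oxazol-5-yl, a 3-ethoxy-1,2-oxazol-5-yl and a 3-amino-1,2-oxazol-5-yl would each bear on this. Nothing available here accounts for these differences in half-life.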